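A small change to the side chain of compound 3

The source may hold more compounds than are shown below. What is called first, only, known or untested is meant among the compounds shown, and "the series" means these compounds.

Measured so far in a functional assay on A-375 cells (Homo sapiens) for inhibition, read by MTT assay, with a stated time of 120 h (on this read-out higher numbers stand for weaker inhibition and lower numbers for stronger inhibition), are these compounds:
compound 1 `C/C(=C\c1ccc(NC(=O)Nc2ccc(Cl)c(C(F)(F)F)c2)cc1)C(=O)NC(C)c1ccccc1` gives > 50000 nM as a limit
compound 2 `O=C(/C=C/c1ccc(NC(=O)Nc2ccc(Cl)c(C(F)(F)F)c2)cc1)NC1CCC1` gives 15400 nM as its value
compound 3 `CNC(=O)/C=C/c1ccc(NC(=O)Nc2ccc(Cl)c(C(F)(F)F)c2)cc1` gives 20900 nM as its value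

On these numbers, compound 3 stands level with compound 2, and no order can be drawn between them. Compound 1 gives > 50000 nM as a limit of the assay and not a number.

Compound 4 `CNC(=O)/C(C)=C/c1ccc(NC(=O)Nc2ccc(Cl)c(C(F)(F)F)c2)cc1` changes one group of compound 3: 2-(methylcarbamoyl)prop-1-en-1-yl in place of 2-(methylcarbamoyl)ethenyl on an aromatic carbon describes it in counts. In words, it has 2-(methylcarbamoyl)prop-1-en-1-yl in place of 2-(methylcarbamoyl)ethenyl on an aromatic carbon.

Among the measured compounds shown here, the only measured step is a 1.4-fold higher number from compound 2 to compound 3 (0.13 log units; within the scatter) and it concerns a different place, methyl in place of cyclobutyl on an amide-type nitrogen. For the measured compounds named here, no measured step therefore tests this change directly. That leaves compound 3 at 20900 nM as the anchor, and no step beyond the scatter is expected in this assay here. The expected step is a 1.2-fold higher number from compound 3 to compound 4 (0.08 log units; within the scatter) and this estimate stays within the scatter. With the limit of > 50000 nM in this assay, at which 1 of the 3 values shown sits, in view, a reading that returns only a limit is also possible. Compound 4 is estimated at 25000 nM with 11000 nM to 50000 nM as the expected range.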

Compound 4, half-maximal inhibitory concentration: > 50000 nM
Compound 4: a limit, no number; the forecaster's own chance of this, stated with the estimate: 30%; middle value at least 2.0-fold (0.30 log units) from the limit.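

Among the compounds shown here, until now, the only measured step lay on the amide nitrogen and stayed within the scatter. In this assay, the chain on the aromatic carbon, para to a large group, does respond: 2-(methylcarbamoyl)prop-1-en-1-yl in place of 2-(methylcarbamoyl)ethenyl gives an at least 2.3-fold higher number from compound 3 to compound 4 (0.37 log units; beyond the scatter), so a single added methyl on the chain is enough to weaken inhibition beyond the scatter. The comparison with the cyclobutyl amide shows the same direction with an at least 3.2-fold higher number from compound 2 to compound 4 (0.51 log units; beyond the scatter), though that pair also differs in the group on the amide nitrogen, and since compound 4 reads only as a limit of the assay and not a number, both steps give a minimum size and not a true one: the limit of > 50000 nM in this assay, at which 2 of the 4 values shown sit.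

The step between compound 1 and compound 4 cannot be read, since both ends are limits, so the group on the amide nitrogen cannot be judged once this methyl is present. On these data alone, whether an ethyl group in place of that methyl, or a carboxylic acid in place of the amide, would behave in the same way stays open.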